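A few compounds are considered here, and "the series" means these few. Any claim that something is new, unique, unknown or untested is made for them only; others in the source may bear on it.

For the measured compounds named here, in a functional assay on HT cells (Homo sapiens) for antiproliferative activity, read by fluorescence, with a stated time of 72 h (on this read-out lower numbers stand for stronger inhibition of growth and higher numbers for weaker inhibition of growth), compound 3 (`CSCCSc1nc(NCc2ccc(-c3ccccn3)cc2)c2[nH]nc(C(C)C)c2n1`) gives 975 nM and stands highest of the three numbers so far. Compound 1 (`CC(C)c1n[nH]c2c(NCc3ccc(-c4ccccn4)cc3)nc(SCCNC(=N)N)nc12`) lies nearest at 390 nM on that scale and compound 2 (`CC(C)c1n[nH]c2c(NCc3ccc(-c4ccccn4)cc3)nc(SC[C@H](O)CN)nc12`) furthest at 63 nM in the same read-out.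

Compound 4 (`COCSc1nc(NCc2ccc(-c3ccccn3)cc2)c2[nH]nc(C(C)C)c2n1`) differs from compound 3 by methoxy in place of (methylsulfanyl)methyl on a saturated chain carbon bound to a sulfur and the change reads as methoxy in place of (methylsulfanyl)methyl on a saturated chain carbon bound to a sulfur.

Going by the values given here, three measured steps bear on this chain: a 2.5-fold higher number from compound 1 to compound 3 (0.40 log units; beyond the scatter) and a 15-fold higher number from compound 2 to compound 3 (1.19 log units; beyond the scatter) along with a 6.2-fold lower number from compound 1 to compound 2 (0.79 log units; beyond the scatter) as the third. All three lie beyond the scatter, and the second is the largest. Each of them involves a chain end holding nitrogen, whereas neither group in the present change holds any. Among the compounds with values here, no measured step exchanges methoxy for another group, so direct evidence for this swap is lacking.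

A step within the scatter is therefore expected in this assay with no clear direction. The expected step is a 1.0-fold higher number from compound 3 to compound 4 (0.01 log units; within the scatter) on this estimate. Compound 4 is estimated at 1000 nM with an expected range from 400 nM to 2500 nM in this series.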

Compound 4, concentration for 50% growth inhibition: 340 nM
Compound 4: the middle estimate sits 2.9-fold (0.47 log units) above what was measured; the measured number lies below the stated range.
By their numbers in this assay, from the lowest: compound 2; then compounds 4 and 1 (each within the scatter of the next); then compound 3.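

In this assay, for the compounds shown here, methoxy in place of (methylsulfanyl)methyl on a saturated chain carbon bound to a sulfur gives a 2.9-fold lower number from compound 3 to compound 4 (0.46 log units; beyond the scatter) and so shows that this position responds to a change between two chain ends that hold no nitrogen, which no earlier step could show. A chain end holding nitrogen is also not required to reach the level of compound 1, as a 1.1-fold lower number from compound 1 to compound 4 (0.06 log units; within the scatter) stays within the scatter, although compound 3 shows that a nitrogen-free end does not guarantee this and 2-amino-1-hydroxyethyl remains ahead, with a 5.4-fold higher number from compound 2 to compound 4 (0.73 log units; beyond the scatter) in the same read-out. Nothing available here accounts for any of these differences.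

On these data alone, in the step to compound 4, oxygen replaces sulfur and the chain shortens at the same time, so the share of each remains open, and a 2-methoxyethyl group or a plain ethyl group on the same sulfur would help to separate them. Also open, as far as these compounds go, is how a simple primary amine, a carboxylic acid or a longer ether chain at this place would compare with the 2-amino-1-hydroxyethyl end of compound 2.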